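Chloro in Place of Fluoro, Measured Next

This account rests on a few compounds, and the source may have more. Where it says the series, first, only, none or still open, it means among the compounds named here.

Compound 1 `O=C(Nc1ccc(F)cc1)N[C@H]1CC[C@H](Oc2ccc(F)cc2)CC1` – in a functional assay on CRL2813 cells (Homo sapiens) for cytotoxicity, read by sulforhodamine B assay, with a stated time of 5 days (on this read-out lower numbers stand for stronger inhibition and higher numbers for weaker inhibition), compound 1 gives 20000 nM
Compound 2 `O=C(Nc1ccccc1C(=O)O)N[C@H]1CC[C@@H](Oc2ccc(F)cc2)CC1` – compound 2 gives > 20000 nM, which is a limit of the assay, not a number
Compound 3 `O=C(Nc1cccc(C(F)(F)F)c1)N[C@H]1CC[C@H](Oc2ccc(C(F)(F)F)cc2)CC1` – compound 3 gives 460 nM

Of the two compounds that give a number in this assay, compound 1 gives the higher one, meaning the weaker cytotoxic effect, and the gap down to compound 3 lies beyond the usual scatter. For compound 2 only the limit of > 20000 nM in this assay, at which 1 of the 3 values shown sits, is known, so it cannot be placed against the others.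

Compound 4 `O=C(Nc1ccc(Cl)cc1)N[C@H]1CC[C@H](Oc2ccc(F)cc2)CC1` is the next compound to go into this assay. It differs from compound 1 in a single place: chloro in place of fluoro on an aromatic carbon. Going by the values given here, no pair of measured compounds differs by this same change, so no measured step shows what to expect from it. The expectation is therefore a modest one: a step that stays within the scatter or only just beyond it, with a slight lean toward a lower number. Compound 4 is expected to give 12000 nM, with a range from 3000 nM to 30000 nM. That estimate means an expected step of a 1.7-fold lower number from compound 1 to compound 4 (0.22 log units; within the scatter).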

Compound 4, half-maximal inhibitory concentration: > 20000 nM
Compound 4 ended at the assay's limit (the forecaster's own chance of this, stated with the estimate: 30%); at least 1.6-fold (0.22 log units) between middle value and limit.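

In this assay compound 4 gives > 20000 nM, which is a limit of the assay and not a number. Going by these compounds alone, exchanging fluoro for chloro at this place, the change from (4-fluorophenyl)amino to (4-chlorophenyl)amino, gives a number no lower from compound 1 to compound 4 (the limit leaves the size open), so this swap, which no earlier pair could test, brings no gain in cytotoxic effect here. The top of the measurable range also now holds more of this small set of compounds: the limit of > 20000 nM in this assay, at which 2 of the 4 values shown sit.

How far compound 4 lies from compound 1 cannot be read, so chloro may change the effect slightly or a great deal in the weaker direction. Going by these compounds, what a methoxy group or an amine would do at this place stays open, as does the same swap of fluoro for chloro on the other fluorinated ring of compound 1.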